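The source may report more compounds than this note shows. Statements on the series, on what has been measured and on what is new or still open speak of the compounds shown alone.

Within the data shown here, compound 1 `Cc1ccc(C2=NN(C3=NC(c4ccccc4)CS3)C(c3ccc4ccccc4c3)C2)cc1` is one of two compounds so far measured in a functional assay on HeLa cells (Homo sapiens) for inhibition, read by CCK-8 assay, with a stated time of 48 h (a lower number here means a stronger inhibitor, a higher number a weaker inhibitor), where compound 1 gives 2460 nM. Compound 2 `Cc1ccc(C2=NN(C3=NC(c4ccccc4)CS3)C(c3cccc4ccccc34)C2)cc1` gives 4290 nM in this assay, and the two numbers lie within the scatter of each other: the step of a 1.7-fold higher number from compound 1 to compound 2 (0.24 log units; within the scatter), with naphthalen-1-yl in place of naphthalen-2-yl on a saturated ring carbon, does not move the number in a meaningful way. Compound 3 `COc1ccc(C2=NN(C3=NC(c4ccccc4)CS3)C(c3ccc4ccccc4c3)C2)cc1` has not yet been measured. It differs from compound 1 in one place: methoxy in place of methyl on an aromatic carbon. Among the measured compounds shown here, no measured step touches this part of the shared core, so nothing measured speaks for or against a shift in either direction. The step of a 1.0-fold higher number from compound 1 to compound 3 (0.01 log units; within the scatter) is therefore estimated to fall within the scatter. Compound 3 is expected to give about 2500 nM in this assay, within a range from 1000 nM to 6500 nM.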

Compound 3, half-maximal inhibitory concentration: 1860 nM
Compound 3: the middle estimate sits 1.3-fold (0.13 log units) above what was measured; the measured number falls inside the stated range.
By their numbers in this assay, from the lowest: compounds 3, 1 and 2 (each within the scatter of the next, the first and the last beyond it).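

Among these compounds, this is the first measured change at the 4-methylphenyl part of the shared core. In this assay, going to 4-methoxyphenyl gives a 1.3-fold lower number from compound 1 to compound 3 (0.12 log units; within the scatter) and so shows that this place, on an aromatic carbon para to a large group, can carry methoxy, with its added oxygen and one more heavy atom, without a meaningful shift in the number. No outside evidence bears on why this swap leaves the number within the scatter.

On these data alone, whether any group at this place can move the number beyond the scatter remains open, and an amine, a carboxylic acid or a longer chain such as butoxy would each test this. Also open, as far as these compounds go, is whether methoxy would behave the same way alongside the naphthalen-1-yl group of compound 2.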